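The source may report more compounds than this note shows. Statements on the series, on what has been measured and on what is new or still open speak of the compounds shown alone.

The series shares the core of compound 1 `c1ccc(-c2nc(-c3c[nH]c4ccccc34)co2)cc1`, which in a functional assay on PC-3 cells (Homo sapiens) for cytotoxicity, read by MTT assay, with a stated time of 48 h (a lower number here means a stronger inhibitor, a higher number a weaker inhibitor), gives 170000 nM. Compound 2 `Fc1ccc(-c2nc(-c3c[nH]c4ccccc34)co2)cc1` carries fluoro in place of hydrogen on an aromatic carbon and in this assay gives 42800 nM, the step being a 4.0-fold lower number from compound 1 to compound 2 (0.60 log units; beyond the scatter). Compound 3 `Oc1ccc(-c2nc(-c3c[nH]c4ccccc34)co2)cc1` carries hydroxy in place of hydrogen on that carbon and in this assay gives 382000 nM; the step from the parent is a 2.2-fold higher number from compound 1 to compound 3 (0.35 log units; beyond the scatter), and against the fluoro compound it is an 8.9-fold higher number from compound 2 to compound 3 (0.95 log units; beyond the scatter). Compound 3 therefore stands at the highest number of the three, with compound 1 nearest to it and compound 2 furthest away.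

Compound 4 `c1ccc2c(-c3coc(-c4ccncc4)n3)c[nH]c2c1`, not yet measured, differs from compound 3 by pyridin-4-yl in place of 4-hydroxyphenyl on an aromatic carbon. Of the measured steps the one bearing directly on this site is a 2.2-fold higher number from compound 1 to compound 3 (0.35 log units; beyond the scatter), the putting on of the hydroxy; taking it away again is expected to undo roughly that amount. For the measured compounds named here, no measured step shows a ring nitrogen in this position, so that part of the change has no precedent here and widens the range. In this assay compound 4 is therefore expected to show a step of a 2.9-fold lower number from compound 3 to compound 4 (0.47 log units; beyond the scatter), landing close to the number of compound 1. The estimate for compound 4 is 130000 nM, with a range from 40000 nM to 400000 nM.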

Compound 4, half-maximal inhibitory concentration: 298000 nM
For compound 4 the middle estimate is 2.3-fold (0.36 log units) below the measured one, and the stated range covers the measured number.
By their numbers in this assay, from the lowest: compound 2; then compounds 1, 4 and 3 (each within the scatter of the next, the first and the last beyond it).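

In this assay, pyridin-4-yl in place of 4-hydroxyphenyl gives a 1.3-fold lower number from compound 3 to compound 4 (0.11 log units; within the scatter), and pyridin-4-yl in place of phenyl gives a 1.8-fold higher number from compound 1 to compound 4 (0.24 log units; within the scatter), so at this place the new ring nitrogen leaves compound 4 within the scatter of both compound 3 and compound 1, even though those two lie beyond the scatter of each other. For the compounds shown here, only the 4-fluorophenyl group is clearly set apart from pyridin-4-yl, with a 7.0-fold higher number from compound 2 to compound 4 (0.84 log units; beyond the scatter), which leaves compound 2 as the one compound whose number is separated from that of compound 4. No measurement shown here accounts for these differences.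

As far as these compounds go, it remains open whether the separation seen with compound 2 is specific to fluoro or also appears with chloro, bromo or trifluoromethyl on the same aromatic ring. Also open, from the compounds shown here alone, are how pyridin-3-yl or pyridin-2-yl, with the ring nitrogen placed elsewhere, compare with pyridin-4-yl, and whether an amine or a carboxylic acid on the phenyl ring stays in the range of compounds 1, 3 and 4.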